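Swapping an aromatic ring for a saturated one

The compounds below may be only part of what the source reports. "The series", "measured", "known", "first", "only" and "open" are said of these compounds alone.

Of the compounds shown here, three built on one shared core have been measured in an in vitro functional assay on cells for agonist activity at Bombesin receptor subtype-3 (Mus musculus), read by luminescence and calcium flux; a lower number here means that less compound is needed, a higher number that more compound is needed for the effect. Compound 1 `O=C(O)c1ccccc1-c1ccc(CCc2ncc(CC3CCC3)[nH]2)cc1` gives 7.1 nM, compound 2 `O=C(O)c1ccccc1-c1ccc(CCc2ncc(Cc3ccccc3Cl)[nH]2)cc1` gives 22 nM, and compound 3 `O=C(O)c1ccccc1-c1ccc(CCc2ncc(CCc3ccccc3)[nH]2)cc1` gives 174 nM, the highest of the three numbers. The steps behind that standing are a 25-fold higher number from compound 1 to compound 3 (1.39 log units; beyond the scatter) and a 7.9-fold higher number from compound 2 to compound 3 (0.90 log units; beyond the scatter), both beyond the scatter. Compound 4 `O=C(O)c1ccccc1-c1ccc(CCc2ncc(CCC3CCCCC3)[nH]2)cc1` differs from compound 3 in a single place: cyclohexyl in place of phenyl on a saturated chain carbon, two bonds along the chain from an aromatic carbon. Among the compounds with values here, no measured pair makes exactly this swap. The nearest guide is a 25-fold higher number from compound 1 to compound 3 (1.39 log units; beyond the scatter), where a saturated ring attached to the chain went with a much lower number than an aromatic one, though that pair also differs in ring size and chain length, so it applies only in part. A saturated ring at the end of the chain is therefore expected to bring the number down by a modest amount, a 2.9-fold lower number from compound 3 to compound 4 (0.46 log units; beyond the scatter). Compound 4 is estimated at 60 nM, with a range from 15 nM to 250 nM.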

Compound 4, half-maximal effective concentration: 33 nM
Beside the measured number, compound 4's estimate is 1.8-fold (0.26 log units) above it; low and high end bracket the measured number.
By their numbers in this assay, from the lowest: compound 1; then compounds 2 and 4 (each within the scatter of the next); then compound 3.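

Holding the chain fixed and changing only the ring shows directly that in this assay, a cyclohexyl at this place goes with a lower number than a phenyl (a 5.3-fold lower number from compound 3 to compound 4 (0.72 log units; beyond the scatter)). A saturated ring alone does not match the best result so far, since cyclohexylmethyl stands above cyclobutyl (a 4.6-fold higher number from compound 1 to compound 4 (0.67 log units; beyond the scatter)). Cyclohexylmethyl and 2-chlorophenyl cannot be told apart in this assay (a 1.5-fold higher number from compound 2 to compound 4 (0.18 log units; within the scatter)), so a saturated ring does not always give a clearly lower number than an aromatic one.

Nothing shown here explains why the saturated ring gives the lower number. As far as these compounds go, it remains open how a cyclopentyl or a piperidine ring would compare at the end of this chain, and whether a longer chain carrying cyclohexyl would lower or raise the number.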